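The source may hold more compounds than are shown below. What is called first, only, known or untested is meant among the compounds shown, and "the series" means these compounds.

Of the compounds shown here, two sharing the same core have been tested in a functional assay on A549 cells (Homo sapiens) for antiproliferative activity, read by MTT assay, with a stated time of 72 h; on this read-out lower numbers stand for stronger inhibition and higher numbers for weaker inhibition. Compound 2 `O=C(Nc1ccc(F)cc1)C(Cl)Cl` gives 68400 nM, the higher of the two numbers. Compound 1 `O=C(Nc1cccc(Br)c1)C(Cl)Cl` gives 7800 nM, and the gap between compound 1 and compound 2 lies beyond the usual scatter. Compound 3 `O=C(Nc1ccc(SC(F)(F)F)cc1)C(Cl)Cl` is compound 2 with (trifluoromethyl)sulfanyl in place of fluoro on an aromatic carbon. Among the measured compounds shown here, no measured pair shows a change of this kind, so its effect is unknown; the two values measured so far only show that the compound with the larger substituent has the lower number. Compound 3 is estimated at 12000 nM, with a range from 4000 nM to 40000 nM. The expected step is a 5.7-fold lower number from compound 2 to compound 3 (0.76 log units; beyond the scatter), toward a lower number and beyond the scatter.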

Compound 3, half-maximal inhibitory concentration: 10600 nM
Beside the measured number, compound 3's estimate is 1.1-fold (0.05 log units) above it, and the stated range covers the measured number.
By their numbers in this assay, from the lowest: compounds 1 and 3 (each within the scatter of the next); then compound 2.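

In this assay, replacing fluoro with (trifluoromethyl)sulfanyl on this aromatic carbon gives a 6.5-fold lower number from compound 2 to compound 3 (0.81 log units; beyond the scatter) as the first step measured at this position. The position therefore accepts a group of five heavy atoms in place of one, and the number falls rather than rises. Nothing available here explains this fall. One step cannot show whether the size of the entering group matters or something else about it. A methoxy group, a nitrile or an amine on the same carbon would extend the comparison.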